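Thienyl aminoketone series: aryl swap at the five-membered ring

The source may hold more compounds than are shown below. What is called first, only, known or untested is meant among the compounds shown, and "the series" means these compounds.

Measured so far:
- compound 1, `Nc1scc(-c2cccc(C(F)(F)F)c2)c1C(=O)c1ccc(Cl)cc1`: 73%
- compound 2, `Nc1scc(-c2ccccc2F)c1C(=O)c1ccc(Cl)cc1`: 87%

In a functional assay on CHO cells for agonist activity at adenosine receptor A1 (Homo sapiens), read by fluorescence and ERK phosphorylation, with stated times of 30 min and 1.5 h, tested at 10 uM (a higher number here means a stronger effect of the compound at the concentration tested, a lower number a weaker effect), compound 2 gives 87%, the highest of the two numbers; compound 1 gives 73%, lower by more than the scatter. Next is compound 3, `Nc1scc(-c2cccc(Br)c2)c1C(=O)c1ccc(Cl)cc1`, differing from compound 2 by 3-bromophenyl in place of 2-fluorophenyl on an aromatic carbon. Going by the values given here, with no measured step of this kind to lean on, a downward move is expected, a number 11 percentage points lower from compound 2 to compound 3 (beyond the scatter), roughly at the edge of the scatter, because compound 1 gives 73%. Compound 3 is thus estimated at 76%, range 58% to 92%.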

Compound 3, a percentage reported as activity, at one concentration (the size of the read-out at that concentration, not a potency): 69%
The estimate for compound 3 lay 7 percentage points above the measured number, within the range that was stated.
By their numbers in this assay, from the lowest: compounds 3 and 1 (each within the scatter of the next); then compound 2.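

At this aromatic carbon, the change to 3-bromophenyl gives a number 18 percentage points lower from compound 2 to compound 3 (beyond the scatter) and so confirms a real drop from the 2-fluorophenyl level, while bromo in place of trifluoromethyl gives a number 4 percentage points lower from compound 1 to compound 3 (within the scatter) and so separates these two groups by nothing beyond the scatter. In the step from compound 2, both the halogen and its place on the phenyl ring change, so the two contributions cannot be separated. Nothing available explains the step.

Open: how 3-fluorophenyl or 2-bromophenyl would read, which would separate halogen from placement. Also open, from the compounds shown here alone, is how far a phenyl ring bearing an amine or a carboxylic acid would carry the effect.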